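The source may report more compounds than this note shows. Statements on the series, on what has been measured and on what is new or still open speak of the compounds shown alone.

Compound 1 `O/N=C/c1ccc(Sc2cc(F)cc(C3CCOCC3)c2)cc1` is the starting point of this step. In a functional assay (blood) for inhibition, with Homo sapiens as the target (a higher number here means a weaker inhibitor, a lower number a stronger inhibitor), compound 1 gives 120 nM, the lowest of the three numbers at hand. Compound 3 `CO[C@]1(c2cnc(S(=O)(=O)c3ccc(/C(C)=N/O)cc3)s2)CCO[C@@H](C)C1`, built on a different core, gives 320 nM in this assay, and compound 2 `C/C(=N\O)c1cccc(Sc2cc(F)cc(C3CCOCC3)c2)c1` gives 2910 nM, both beyond the scatter from compound 1. Compound 4 `C/C(=N\OCC(=O)O)c1ccc(Sc2cc(F)cc(C3CCOCC3)c2)cc1` has not yet been measured in this assay. It differs from compound 1 in one place: a group of 8 heavy atoms (4 carbon, 1 nitrogen, 3 oxygen; no ring) in place of a group of 3 heavy atoms (1 carbon, 1 nitrogen, 1 oxygen; no ring), on an aromatic carbon. For the measured compounds named here, no measured pair shows this exact change, so the size of the step is uncertain; a moderate loss is expected, so that the step from compound 1 to compound 4 is estimated at a 3.3-fold higher number from compound 1 to compound 4 (0.52 log units; beyond the scatter). Compound 4 is therefore expected to give about 400 nM, within 100 nM to 2000 nM.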

Compound 4, half-maximal inhibitory concentration: 740 nM
Compound 4: the middle estimate sits 1.9-fold (0.27 log units) below what was measured; measured number inside the range.
By their numbers in this assay, from the lowest: compound 1; then compound 3; then compound 4; then compound 2.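

For the compounds shown here, the first reading at this position, on an aromatic carbon para to a large group, shows that in this assay the larger group of 8 heavy atoms costs a modest amount: a 6.2-fold higher number from compound 1 to compound 4 (0.79 log units; beyond the scatter) is the step on the shared core. The change replaces the whole group at once, so this single step cannot be divided among its parts. No measurement here bears on its cause. On these data alone, whether an amide or an amine at the end of the chain, or a longer chain, would narrow this step remains open. So does whether the same change would behave alike on the other cores.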